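The source may report more compounds than this note shows. Statements on the series, on what has been measured and on what is new or still open speak of the compounds shown alone.

Measured so far in an assay on isolated protein for activation of cGMP-dependent protein kinase 1 (Homo sapiens), read by ADP-Glo, with stated times of 30 min and 2 h, in the presence of a further agent that is not named here; a lower number here means that less compound is needed, a higher number that more compound is needed for the effect: compound 1 `OC[C@@H](O[C@H]1CCCN(Cc2ncc[nH]2)[C@H]1c1ccccc1)c1cc(Cl)cc(Cl)c1` gives 47000 nM; compound 2 `Cc1cc(C(=O)O)ccc1CN1CCC[C@H](O[C@H](CO)c2cc(Cl)nc(Cl)c2)[C@@H]1c1ccccc1` gives 2400 nM; compound 3 `Cc1cc(C(=O)O)ccc1CN1CCC[C@H](OC(c2cc(Cl)cc(Cl)c2)C(C)O)[C@@H]1c1ccccc1` gives 5300 nM.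

Compound 1 stands highest of the three in this assay, well above compound 2 and compound 3. Compound 4 `Nc1cc(C(=O)O)ccc1CN1CCC[C@H](O[C@H](CO)c2cc(Cl)cc(Cl)c2)[C@@H]1c1ccccc1` differs from compound 1 by 2-amino-4-carboxyphenyl in place of 1H-imidazol-2-yl on a saturated chain carbon bound to an amine nitrogen in a ring. Within the data shown here, no measured step changes this group alone: compound 2 and compound 3 each carry on the ring nitrogen a benzyl group bearing a carboxylic acid, together with further changes elsewhere, and both sit far below compound 1. Among the measured compounds shown here, the single measured step, a 2.2-fold higher number from compound 2 to compound 3 (0.34 log units; beyond the scatter), concerns the aryl group on the ether oxygen and bears only indirectly. For compound 4 a large drop in this assay is expected, a 16-fold lower number from compound 1 to compound 4 (1.19 log units; beyond the scatter). Compound 4 is estimated at 3000 nM, range 800 nM to 12000 nM.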

Compound 4, half-maximal effective concentration in the cGMP-dependent protein kinase 1 assay: 290 nM
Compound 4: the middle estimate sits 10-fold (1.01 log units) above what was measured; the measured number lies below the stated range.
By their numbers in the cGMP-dependent protein kinase 1 assay, from the lowest: compound 4; then compound 2; then compound 3; then compound 1.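

In the cGMP-dependent protein kinase 1 assay, compound 1 gives 47000 nM and compound 4 gives 290 nM, and 2-amino-4-carboxyphenyl in place of 1H-imidazol-2-yl on a saturated chain carbon bound to an amine nitrogen in a ring gives a 160-fold lower number from compound 1 to compound 4 (2.21 log units; beyond the scatter). Among these compounds, this is the first reading of this position with nothing else in the structure altered, so the whole step belongs to this one change. In a physicochemical assay for solubility, at pH 7 (on this read-out higher numbers stand for higher solubility and lower numbers for lower solubility), compound 1 gives 120000 nM and compound 4 gives 78000 nM, and the same change gives a 1.5-fold lower number from compound 1 to compound 4 (0.19 log units; within the scatter), so this pair shows no real difference on that read-out. No evidence on hand gives a reason for the step. Going by these compounds, whether the amine or the carboxylic acid of the new group carries the step stays open, as does the outcome with a sulfonamide in place of that carboxylic acid.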